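Phenyl in Place of tert-Butyl on an Amide-Type Nitrogen

A few compounds are considered here, and "the series" means these few. Any claim that something is new, unique, unknown or untested is made for them only; others in the source may bear on it.

Three compounds have been measured in a functional assay on MOLT-4F cells (Homo sapiens) for inhibition; a higher number here means a weaker inhibitor, a lower number a stronger inhibitor:

Compound 1, `C/C(=C\COC(=O)NC(C)(C)C)C1=CC(=O)C(C)(C)O1`, gives 6.1 ug/mL.
Compound 2, `CCCCNC(=O)OC/C=C(\C)C1=CC(=O)C(C)(C)O1`, gives 5.3 ug/mL.
Compound 3, `COc1ccc(/C=C/C=C(\C)C2=CC(=O)C(C)(C)O2)cc1`, gives 10 ug/mL.

Compound 1 stands second highest of these three numbers. Its nearest neighbour is compound 2, reached by the step of a 1.2-fold lower number from compound 1 to compound 2 (0.06 log units; within the scatter), a change of butyl for tert-butyl on the amide-type nitrogen. Compound 3 lies furthest from compound 1, yet the gap between the two values also stays within the scatter, so the three measured compounds cannot be ordered against one another.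

Compound 4, `C/C(=C\COC(=O)Nc1ccccc1)C1=CC(=O)C(C)(C)O1`, is the compound not yet measured. It differs from compound 1 in this way: phenyl in place of tert-butyl on an amide-type nitrogen.

For the measured compounds named here, the only measured step at the same nitrogen is a 1.2-fold lower number from compound 1 to compound 2 (0.06 log units; within the scatter), and it did not move the number beyond the scatter. No measured step exchanges an alkyl for an aromatic group at that position, so the direction of any shift is not shown by the data. Compound 4 is therefore expected to sit close to compound 1, with a step of a 1.1-fold lower number from compound 1 to compound 4 (0.04 log units; within the scatter) that is not expected to pass the scatter. The estimate for compound 4 is 5.5 ug/mL, with a range from 2 ug/mL to 15 ug/mL.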

Compound 4, half-maximal inhibitory concentration: > 200 ug/mL
Compound 4: a limit, no number (the forecaster's own chance of this, stated with the estimate: 5%); middle value at least 36-fold (1.56 log units) from the limit.
By their numbers in this assay, from the lowest: compounds 2, 1 and 3 (each within the scatter of the next). At a limit, above all of these: compound 4.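

For the compounds shown here, at this amide-type nitrogen, the earlier compounds showed only that one alkyl group could replace another, with tert-butyl and butyl giving values within the scatter of each other. Phenyl is the first group at this position to show a large change: exchanging tert-butyl for phenyl gives an at least 32-fold higher number from compound 1 to compound 4 (1.51 log units; beyond the scatter), and exchanging butyl for phenyl gives an at least 37-fold higher number from compound 2 to compound 4 (1.57 log units; beyond the scatter), so the position does not accept every group equally, although the core of compound 1 is unchanged. Compound 4 stands at a limit and not at a number in this assay, so both steps give only a lower bound on the size of the change: the limit of > 200 ug/mL in this assay, at which 1 of the 4 values shown sits.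

With a single aromatic group at this position, the compounds shown do not separate the effect of the aromatic ring from that of other features of the phenyl group. From the compounds shown here alone, whether a cyclohexyl or a benzyl group on the same nitrogen would stay close to compound 1 and compound 2 or would instead reach a limit like compound 4 remains open.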